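This account rests on a few compounds, and the source may have more. Where it says the series, first, only, none or still open, it means among the compounds named here.

Measured so far: compound 1 `CCn1cnc2c(N)nc(N)nc21` at > 100000 nM; compound 2 `CC[C@H](N)COc1nc(NC(=N)N)c2ncn(C(C)C)c2n1` at 16300 nM.

In a functional assay on MCF7 cells (Homo sapiens) for inhibition, read by fluorescence, with a stated time of 72 h (on this read-out higher numbers stand for weaker inhibition and lower numbers for stronger inhibition), compound 1 gives a limit of the assay, > 100000 nM, which is the limit of > 100000 nM in this assay, at which 1 of the 2 values shown sits. Among the measured compounds shown here, compound 2 holds the only actual number, giving 16300 nM in this assay. Compound 3 `CC(C)n1cnc2c(NC(=N)N)nc(N3CCC[C@@H]3CO)nc21` differs from compound 2 in one place: 2-(hydroxymethyl)pyrrolidin-1-yl in place of 2-aminobutoxy on an aromatic carbon. For the measured compounds named here, no step between measured compounds exists for comparison, so the change is expected to shift this assay by little beyond the scatter, in no firm direction. The expected step is a 1.4-fold lower number from compound 2 to compound 3 (0.13 log units; within the scatter). Compound 3 is therefore estimated at 12000 nM, within a range from 2500 nM to 60000 nM.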

Compound 3, half-maximal inhibitory concentration: 20400 nM
Compound 3: the middle estimate sits 1.7-fold (0.23 log units) below what was measured; low and high end bracket the measured number.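

In this assay, putting 2-(hydroxymethyl)pyrrolidin-1-yl in place of 2-aminobutoxy on this aromatic carbon between two ring nitrogen atoms gives a 1.3-fold higher number from compound 2 to compound 3 (0.10 log units; within the scatter). Among the compounds shown here, this is the first step read at this position, and it shows that the position accepts a five-membered non-aromatic ring as well as an open chain, with the two values not told apart. No measured property shown here bears on this result.

The compounds shown leave open whether a phenyl ring, a carboxylic acid or a longer chain on this carbon would move the number beyond the scatter. Going by these compounds, what the defined stereocentre in each group contributes also remains open.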